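The source may hold more compounds than are shown below. What is called first, only, known or untested is meant among the compounds shown, and "the series" means these compounds.

Measured so far in a functional assay on cells for agonist activity at Free fatty acid receptor 1 (Homo sapiens), read by FLIPR and calcium flux, with a stated time of 100 s; on this read-out higher numbers stand for an effect only at larger amounts of compound and lower numbers for an effect already at smaller amounts:
compound 1 `Cc1ccccc1Oc1ccc(N2C[C@@H](C(F)(F)F)C[C@H]2CC(=O)O)cc1`, 73 nM
compound 2 `O=C(O)C[C@@H]1C[C@H](C(F)(F)F)CN1c1ccc(Oc2ccccc2C(F)(F)F)cc1`, 310 nM
compound 3 `Cc1cccc(Oc2ccc(N3C[C@@H](C(F)(F)F)C[C@H]3CC(=O)O)cc2)c1C`, 110 nM

Compound 3 stands second highest of the three, close to compound 1 and further from compound 2: the step of a 1.5-fold higher number from compound 1 to compound 3 (0.18 log units; within the scatter) is within the scatter, whereas a 2.8-fold lower number from compound 2 to compound 3 (0.45 log units; beyond the scatter) is beyond it. Compound 4 `Cc1cccc(C)c1Oc1ccc(N2C[C@@H](C(F)(F)F)C[C@H]2CC(=O)O)cc1` differs from compound 3 only by 2,6-dimethylphenyl in place of 2,3-dimethylphenyl on an oxygen on an aromatic ring. The step that bears on this is a 1.5-fold higher number from compound 1 to compound 3 (0.18 log units; within the scatter), where a methyl was added on an aromatic carbon without a change beyond the scatter; moving a methyl within the same ring is expected to matter no more. Compound 4 is therefore expected to give 100 nM in this assay, within 40 nM to 250 nM, a step of a 1.1-fold lower number from compound 3 to compound 4 (0.04 log units; within the scatter) that should stay within the scatter.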

Compound 4, half-maximal effective concentration: 82 nM
Estimate against measurement, compound 4: 1.2-fold (0.09 log units) above; the range from low to high includes it.
By their numbers in this assay, from the lowest: compounds 1, 4 and 3 (each within the scatter of the next); then compound 2.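

In this assay, 2,6-dimethylphenyl in place of 2,3-dimethylphenyl gives a 1.3-fold lower number from compound 3 to compound 4 (0.13 log units; within the scatter), and adding a methyl on an aromatic carbon gives a 1.1-fold higher number from compound 1 to compound 4 (0.05 log units; within the scatter), so on this ring neither where the second methyl sits nor its presence moves the number beyond the scatter in these compounds. Only the trifluoromethyl compound stands apart, with 2,6-dimethylphenyl in place of 2-(trifluoromethyl)phenyl giving a 3.8-fold lower number from compound 2 to compound 4 (0.58 log units; beyond the scatter). No measurement shown here explains these steps.

Open, going by these compounds, is whether a methoxy group, a chlorine atom or a nitrile on this ring would stay with the methyl compounds or sit with compound 2. Also open, on these data alone, is how a third methyl on the ring would read.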